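Bile acid receptor binding: replacing a biaryl with a cinnamate ester

This account rests on a few compounds, and the source may have more. Where it says the series, first, only, none or still open, it means among the compounds named here.

In an assay on isolated protein with Bile acid receptor (Homo sapiens) as the target (on this read-out higher numbers stand for an effect only at larger amounts of compound and lower numbers for an effect already at smaller amounts), three compounds have been measured:
compound 1 `CCOc1cccc(-c2ccc(CN(C(=O)C3CCCCC3)c3cccc(/C=C/C(=O)OC)c3)cc2)c1` — 147 nM
compound 2 `COC(=O)/C=C/c1cccc(N(Cc2ccc(-c3c(OC)cccc3OC)cc2)C(=O)C2CCCCC2)c1` — 77 nM
compound 3 `COC(=O)/C=C/c1cccc(N(Cc2ccc(-c3ccc(C(C)(C)C)cc3)cc2)C(=O)C2CCCCC2)c1` — 132 nM

Compound 3 stands second highest of the three numbers; its nearest neighbour is compound 1 a 1.1-fold lower number from compound 1 to compound 3 (0.05 log units; within the scatter), and the step of a 1.7-fold higher number from compound 2 to compound 3 (0.23 log units; within the scatter) is also within the scatter, as is a 1.9-fold lower number from compound 1 to compound 2 (0.28 log units; within the scatter). Among these compounds, then, exchanging one aryl group for another on the shared core has left the number essentially unchanged.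

Compound 4 `COC(=O)/C=C/c1cccc(N(Cc2ccc(/C=C/C(=O)OCc3ccccc3)cc2)C(=O)C2CCCCC2)c1` differs from compound 3 by a single change: 2-(benzyloxycarbonyl)ethenyl in place of 4-(tert-butyl)phenyl on an aromatic carbon. Within the data shown here, none of the measured steps covers this kind of exchange, in which the aryl group is replaced by a chain rather than by another aryl group, so the measured steps give only indirect guidance. Because a 1.7-fold higher number from compound 2 to compound 3 (0.23 log units; within the scatter) and the other measured changes at this position stayed within the scatter, compound 4 is expected to stay within the same region, with the step of a 1.5-fold higher number from compound 3 to compound 4 (0.18 log units; within the scatter) estimated to be small but with wide uncertainty. Compound 4 is estimated at 200 nM, with a range from 50 nM to 800 nM in this assay.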

Compound 4, half-maximal effective concentration: > 1000 nM
Compound 4: a limit, no number; the forecaster's own chance of this, stated with the estimate: 10%; middle value at least 5.0-fold (0.69 log units) from the limit.
By their numbers in this assay, from the lowest: compounds 2, 3 and 1 (each within the scatter of the next). At a limit, above all of these: compound 4.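

In this assay compound 4 gives a limit and not a number: the limit of > 1000 nM in this assay, at which 1 of the 4 values shown sits.

The exchanges among aryl groups at this position all stayed within the scatter, but replacing any of them with 2-(benzyloxycarbonyl)ethenyl does not, as the steps show: an at least 7.5-fold higher number from compound 3 to compound 4 (0.87 log units; beyond the scatter), an at least 12-fold higher number from compound 2 to compound 4 (1.11 log units; beyond the scatter) and an at least 6.8-fold higher number from compound 1 to compound 4 (0.83 log units; beyond the scatter). The position therefore accepts the three aryl groups shown but not every group, and keeping a six-membered aromatic ring of carbon only in the entering group did not hold the number in the range of compounds 1, 2 and 3.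

Going by these compounds, how far the true value of compound 4 lies past the limit remains open. So does which part of the entering group matters, the ethenyl chain or the benzyl ester, and a methyl ester or a carboxylic acid at the end of that chain would bear on this.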